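From benzyl to isopentyl on the amide

The source may hold more compounds than are shown below. What is called first, only, known or untested is meant among the compounds shown, and "the series" means these compounds.

Three compounds built on a shared core have been examined in an ADME assay on J774.A1 cells (Mus musculus) for cytotoxicity, read by MTT assay, with a stated time of 48 h (on this read-out higher numbers stand for lower toxicity in this test and lower numbers for higher toxicity in this test), and only one of them gave a number. Compound 2 (`COC(=O)c1c([N+](=O)[O-])noc1-c1cccc(-c2ncoc2C)c1`) reads 18500 nM. Compound 1 (`COC(=O)c1c([N+](=O)[O-])noc1-c1ccc(Cl)cc1`) carries only the entry "not determined" (no result reported). Compound 3 (`O=C(NCc1ccccc1)c1c([N+](=O)[O-])noc1-c1ccc([N+](=O)[O-])cc1`) likewise carries only the entry "not determined" (no result reported), so it has no place on the scale and cannot be ranked against compound 2.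

Compound 4 (`CC(C)CCNC(=O)c1c([N+](=O)[O-])noc1-c1ccc([N+](=O)[O-])cc1`) has yet to be measured. The structural change is isobutyl in place of phenyl on a saturated chain carbon bound to an amide-type nitrogen, which, cut one bond further out, reads benzyl to isopentyl. Going by the values given here, no two measured compounds differ in a single place, so the data hold no precedent for this change. With no number for compound 3 as a starting point, no direction can be argued, and no step beyond the usual scatter is expected in this assay. Among the compounds with values here, the only available anchor is compound 2 at 18500 nM, although its structure differs from the amides in more than one place, so the range must stay wide. Compound 4 is expected at an estimated 20000 nM, within a range of 6000 nM to 60000 nM.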

Compound 4, half-maximal cytotoxic concentration: 67000 nM
Beside the measured number, compound 4's estimate is 3.4-fold (0.53 log units) below it, and the stated range ends below it.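

Going by these compounds alone, compound 3 has no single number in this assay, so compound 4 at 67000 nM gives no step that can be read between the two. The compounds shown leave open how going from benzyl to isopentyl on the amide alters toxicity in this test. No evidence shown here bears on this result.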